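Methylimidazole for Trifluoromethyl on a Shared Anilide Core

The source may report more compounds than this note shows. Statements on the series, on what has been measured and on what is new or still open speak of the compounds shown alone.

Of the compounds shown here, two have been measured. Compound 1 `CC(=O)Nc1ncnc2c1ccn2-c1ccc(NC(=O)c2ccc(Cl)c(C(F)(F)F)c2)cc1` carries an acetamide on the shared core. In an ADME assay on HS27 cells (Homo sapiens) for antiproliferative activity, read by MTT assay, with a stated time of 24 h (on this read-out higher numbers stand for weaker inhibition and lower numbers for stronger inhibition), compound 1 reaches only the limit of the assay, > 10000 nM. Compound 2 `O=C(Nc1ccc(-n2ccc3c(NC(=O)c4ccccc4)ncnc32)cc1)c1cc(C(F)(F)F)cc(C(F)(F)F)c1` carries a benzamide on the same core and a bis-trifluoromethyl anilide; in this assay compound 2 gives 6600 nM. For the measured compounds named here, this is the only number reported, since the other reported value, (the limit of > 10000 nM in this assay, at which 1 of the 2 values shown sits), is a limit and not a number, so compound 2 stands alone with a measured value. Compound 3 `Cc1cn(-c2cc(C(=O)Nc3ccc(-n4ccc5c(NC(=O)c6ccccc6)ncnc54)cc3)cc(C(F)(F)F)c2)cn1` has not been measured. It differs from compound 2 in one place, (4-methyl-1H-imidazol-1-yl in place of trifluoromethyl on an aromatic carbon), that is, 4-methyl-1H-imidazol-1-yl in place of trifluoromethyl on an aromatic carbon. Going by the values given here, no step between measured compounds is available to guide the change, so the step from compound 2 to compound 3 in this assay is expected to be small, a 1.4-fold higher number from compound 2 to compound 3 (0.13 log units; within the scatter), toward weaker inhibition or none beyond the scatter. Compound 3 is therefore estimated at 9000 nM, with a range from 3000 nM to 30000 nM.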

Compound 3, half-maximal inhibitory concentration: 2800 nM
Estimate against measurement, compound 3: 3.2-fold (0.51 log units) above, and the stated range ends above it.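

In this assay the series now has its first readable step: 4-methyl-1H-imidazol-1-yl in place of trifluoromethyl on an aromatic carbon gives a 2.4-fold lower number from compound 2 to compound 3 (0.37 log units; beyond the scatter), a modest move toward stronger inhibition. This shows that the position, meta to a large group and meta to a trifluoromethyl group, accepts a five-membered aromatic ring with 2 hetero atoms without loss of inhibition, so the trifluoromethyl group that leaves is not required there for the level seen with compound 2. Nothing shown here accounts for the size or direction of this step.

The compounds shown leave open whether the step belongs to the imidazole ring itself or to its methyl group, since an unsubstituted imidazole does not stand among them. They also leave open how an amine such as morpholine or a carboxylic acid would read at this position, and whether the remaining trifluoromethyl group can be exchanged in the same way.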